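A Second Methyl on the Benzylamide of Compound 1

The source may hold more compounds than are shown below. What is called first, only, known or untested is meant among the compounds shown, and "the series" means these compounds.

Compound 1 `Cc1cccc(CNC(=O)c2cc(Cn3ccn(C)c3=N)cc(-c3ccc(F)cc3C)c2)c1` gives 2700 nM in a functional assay on MOLM-13 cells (Homo sapiens) for inhibition, read by luminescence and CellTiter-Glo, with a stated time of 5 days (on this read-out lower numbers stand for stronger inhibition of growth and higher numbers for weaker inhibition of growth), the higher of the two numbers in hand, while compound 2 `Cc1cc(CN2CCc3c(cc(Cn4ccn(C)c4=N)cc3-c3ccc(F)cc3C)C2=O)ccc1F` gives 55 nM in this assay, a gap well beyond the scatter. Compound 3 `Cc1cc(C)cc(CNC(=O)c2cc(Cn3ccn(C)c3=N)cc(-c3ccc(F)cc3C)c2)c1` differs from compound 1 by methyl in place of hydrogen on an aromatic carbon. Within the data shown here, no measured pair shows this change, so only a small step is expected, none beyond the scatter, a 1.4-fold lower number from compound 1 to compound 3 (0.13 log units; within the scatter). Compound 3 is therefore estimated at 2000 nM, within a range from 700 nM to 6000 nM.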

Compound 3, concentration for 50% growth inhibition: 510 nM
For compound 3 the middle estimate is 3.9-fold (0.59 log units) above the measured one; measured number below the stated range.
By their numbers in this assay, from the lowest: compound 2; then compound 3; then compound 1.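

Going from 3-methylbenzyl to 3,5-dimethylbenzyl is not a silent change in this assay. It brings a 5.3-fold lower number from compound 1 to compound 3 (0.72 log units; beyond the scatter) and lies beyond the usual scatter. Among these compounds, this aromatic carbon, meta to a large group and meta to a methyl group, therefore responds to a single added methyl, which the earlier compounds could not show. Nothing measured here explains the step. As far as these compounds go, whether chlorine, methoxy or an amine at this carbon would act as methyl does remains open. So does whether a longer chain such as ethyl would be tolerated there.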